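From 3,4-Dimethoxyphenyl to Phenyl on the Long-Chain Amide

This account rests on a few compounds, and the source may have more. Where it says the series, first, only, none or still open, it means among the compounds named here.

In a functional assay on cells (Homo sapiens) for antiproliferative activity, read by sulforhodamine B assay, with a stated time of 48 h (a higher number here means a weaker inhibitor, a lower number a stronger inhibitor), compound 1 (`CCCCCCCCCCNC(=O)[C@@H]1CSC(c2ccc(OC)c(OC)c2)N1`) gives 11900 nM and compound 2 (`CCCCCCCCCCCCCCNC(=O)[C@@H]1CSC(c2ccc(OC)c(OC)c2)N1`) gives 1500 nM (the lower of the two numbers). Among the compounds with values here, the only measured step is a 7.9-fold lower number from compound 1 to compound 2 (0.90 log units; beyond the scatter) (a change in the chain, not in the aryl group). Compound 3 (`CCCCCCCCCCCCCCNC(=O)[C@@H]1CSC(c2ccccc2)N1`) keeps the chain of compound 2 but has phenyl in place of 3,4-dimethoxyphenyl on a saturated ring carbon. Within the data shown here, no measured step bears on this place, so no step beyond the scatter is expected in this assay. The estimated step is a 1.3-fold higher number from compound 2 to compound 3 (0.12 log units; within the scatter) (weakly held, towards a higher number). The estimate for compound 3 is 2000 nM (expected range 700 nM to 6000 nM).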

Compound 3, half-maximal inhibitory concentration: 1900 nM
Compound 3: the middle estimate sits 1.1-fold (0.02 log units) above what was measured, and the stated range covers the measured number.
By their numbers in this assay, from the lowest: compounds 2 and 3 (each within the scatter of the next); then compound 1.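

Within this assay, the aryl group on the saturated ring carbon is changed for the first time, and the result is a 1.3-fold higher number from compound 2 to compound 3 (0.10 log units; within the scatter) with the long chain held fixed. With this chain, then, the 3,4-dimethoxyphenyl group can give way to phenyl without a change beyond the scatter. Nothing available explains this result.

From the compounds shown here alone, whether phenyl behaves the same way on the shorter chain of compound 1 remains open. Also open, going by these compounds, is what a pyridine ring or a phenyl bearing a carboxylic acid would do at this position.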